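The source may report more compounds than this note shows. Statements on the series, on what has been measured and on what is new or still open speak of the compounds shown alone.

In a functional assay on the whole organism (Tail, strain ICR) with Mus musculus as the target, in the tail flick test, with a stated time of 60 min, at a dose of 25 umol/kg by the oral route (on this read-out lower numbers stand for a weaker effect and higher numbers for a stronger effect at the one dose given), three compounds have been measured so far:
compound 1 `NC(=O)C[C@H](NC(=O)CN(c1nc(Cl)nc2[nH]cnc12)C1CC1)C(=O)O` gives 43.1%;
compound 2 `CC(C)[C@H](NC(=O)CN(c1nc(Cl)nc2[nH]cnc12)C1CC1)C(=O)O` gives 38.8%;
compound 3 `CSCC[C@H](NC(=O)CN(c1nc(Cl)nc2[nH]cnc12)C1CC1)C(=O)O` gives 22.8%.

Compound 3 stands lowest of the three, with both a number 20.3 percentage points lower from compound 1 to compound 3 (beyond the scatter) and a number 16 percentage points lower from compound 2 to compound 3 (beyond the scatter) lying beyond the scatter. Compound 4 `CC(C)C[C@H](NC(=O)CN(c1nc(Cl)nc2[nH]cnc12)C1CC1)C(=O)O` has not yet been measured. It differs from compound 3 in one place: isopropyl in place of (methylsulfanyl)methyl on a saturated chain carbon, two bonds along the chain from an amide-type nitrogen and a carbonyl carbon. The measured step bearing most directly on this change is a number 16 percentage points lower from compound 2 to compound 3 (beyond the scatter), which brought in the (methylsulfanyl)methyl group that compound 4 now loses; the change from compound 3 to compound 4 runs that exchange the other way. A modest rise in this assay is therefore expected, a number 14.2 percentage points higher from compound 3 to compound 4 (beyond the scatter). Compound 4 is estimated at 37%, with a range from 24% to 50%.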

Compound 4, a percentage reported as activity, at one dose (the size of the read-out at that dose, not a potency): 36.4%
For compound 4 the middle estimate is 0.6 percentage points above the measured one; the range from low to high includes it.
By their numbers in this assay, from the lowest: compound 3; then compounds 4, 2 and 1 (each within the scatter of the next).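

In this assay, at this place on the chain, the exchange of (methylsulfanyl)methyl for isopropyl gives a number 13.6 percentage points higher from compound 3 to compound 4 (beyond the scatter) and so ties the low value of compound 3 to a sulfur-bearing chain, since the two groups count the same heavy atoms. The isobutyl side chain also gives a number 2.4 percentage points lower from compound 2 to compound 4 (within the scatter) and a number 6.7 percentage points lower from compound 1 to compound 4 (within the scatter), which leaves compound 3 alone apart from the others. Nothing available explains why this exchange matters.

The compounds shown leave open whether a methoxy group in place of methylsulfanyl would keep the low value of compound 3, and whether an amine, a carboxylic acid or a longer chain at this place would match compound 4.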